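This account rests on a few compounds, and the source may have more. Where it says the series, first, only, none or still open, it means among the compounds named here.

Compound 1 `Nc1nn(C(=O)Nc2ccc(Cc3ccccc3)cc2)c2ccccc12` sets the baseline of the series. In a functional assay on EKVX cells (Homo sapiens) for antiproliferative activity, read by sulforhodamine B assay, with a stated time of 48 h (a higher number here means that more compound is tolerated, a lower number that less compound is tolerated), compound 1 gives only a limit, > 100000 nM. Compound 2 `Nc1nn(C(=O)Nc2ccc(Cc3ccccc3)cc2)c2ccc(Cl)cc12` carries a chloro in place of hydrogen on an aromatic carbon. In this assay compound 2 likewise gives only a limit, > 100000 nM. The step that the two limits leave unreadable from compound 1 to compound 2 therefore cannot be sized, because both values sit at the limit of > 100000 nM in this assay, at which 2 of the 2 values shown sit. Within the data shown here, compound 2 thus stands at the limit with no number of its own, and the one other value shown is the same limit.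

Compound 3 `Nc1ccc2c(c1)c(N)nn2C(=O)Nc1ccc(Cc2ccccc2)cc1` differs from compound 2 by amino in place of chloro on an aromatic carbon. Among the measured compounds shown here, the only measured step that bears on this change is a step that the two limits leave unreadable from compound 1 to compound 2, and it is unreadable. No shown change moved either compound off the limit. For compound 3 the expected step is a number no higher from compound 2 to compound 3 (the limit leaves the size open), none beyond the scatter, most likely again a limit. Compound 3 is estimated at 100000 nM, between 30000 nM and 300000 nM.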

Compound 3, concentration lethal to 50% of the cells: 96100 nM
Beside the measured number, compound 3's estimate is 1.0-fold (0.02 log units) above it, within the range that was stated.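

In this assay compound 3 gives 96100 nM, the only actual number among the compounds shown, so this aromatic carbon can carry an amino group with a value that falls inside the measured range. Amino in place of chloro gives an at least 1.0-fold lower number from compound 2 to compound 3 (0.01 log units; that floor lies within the scatter), and amino in place of hydrogen gives an at least 1.0-fold lower number from compound 1 to compound 3 (0.01 log units; that floor lies within the scatter); each of these is a floor and not a size. Compound 1 and compound 2 have no number of their own, so the true size of both steps stays open: the limit of > 100000 nM in this assay, at which 2 of the 3 values shown sit.

From the compounds shown here alone, whether any change at this position moves the value clearly beyond the scatter remains open. A hydroxyl, a methoxy or an acetamide on the same aromatic carbon would test whether the number of compound 3 is particular to the amino group.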